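This account rests on a few compounds, and the source may have more. Where it says the series, first, only, none or still open, it means among the compounds named here.

Measured so far in a functional assay on TREX cells for negative allosteric modulation of metabotropic glutamate receptor 3 (Rattus norvegicus), read by calcium flux, with a stated time of 2.5 min; on this read-out higher numbers stand for weaker inhibition and lower numbers for stronger inhibition:
Compound 1, `COc1ccc(C#Cc2ccc(C(=O)N3CCCC(OC)C3)cc2)cc1`, gives 5500 nM.
Compound 3, `COc1ccc(C#Cc2ccc(C(=O)N3CCC[C@@H](O)C3)c(F)c2)cc1`, gives 450 nM; 593 nM; 603 nM (3 entries).
Compound 2, `CSc1ccc(C#Cc2ccc(C(=O)N3CCC[C@@H](CO)C3)cc2)cc1`, reaches only a limit in this assay, > 10000 nM.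

Compound 2 thus stands at the limit rather than at a number, the same limit noted in the limit of > 10000 nM in this assay, at which 1 of the 3 values shown sits. Compound 1 and compound 3 carry a different set of changes, so their values say nothing directly about compound 2; they only mark where other members of this series sit, compound 3 with the repeated entries of the several entries of compound 3 in this assay, 450 nM; 593 nM; 603 nM (3 entries).

The unmeasured compound 4, `COc1ccc(C#Cc2ccc(C(=O)N3CCC[C@@H](CO)C3)cc2)cn1`, differs from compound 2 in one place: 6-methoxypyridin-3-yl in place of 4-(methylsulfanyl)phenyl on a triple-bonded carbon. Within the data shown here, no pair of measured compounds shows this exchange, so the size of the step in this assay cannot be read from the data. Given that compound 2 sits at the limit, a moderate gain toward a measurable number is expected, with a real chance that compound 4 also returns only a limit. The expected step is an at least 2.0-fold lower number from compound 2 to compound 4 (0.30 log units; that floor lies within the scatter). For compound 4 the estimate in this assay is 5000 nM, between 1500 nM and 15000 nM.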

Compound 4, half-maximal inhibitory concentration: > 10000 nM
Compound 4 was reported as a limit; the forecaster's own chance of this, stated with the estimate: 40%; middle value at least 2.0-fold (0.30 log units) from the limit.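

In this assay compound 2 stands at a limit, > 10000 nM, not at a number. Compound 4 also returns only a limit, > 10000 nM, so no step can be read between compound 2 and compound 4. The compounds shown leave open whether exchanging 4-(methylsulfanyl)phenyl for 6-methoxypyridin-3-yl changes inhibition at all, and in which direction.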